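Lengthening the urea substituent in an aminothiazole H2 agonist series

A few compounds are considered here, and "the series" means these few. Any claim that something is new, unique, unknown or untested is made for them only; others in the source may bear on it.

Measured compounds:
- Compound 1, `CCCNC(=O)/N=C(\N)NCCCc1sc(N)nc1C`: 0.32
- Compound 2, `CCCCCCNC(=O)/N=C(\N)Nc1cccc(-c2csc(N)n2)c1`: "not determined" (no result reported)
- Compound 3, `N/C(=N\C(=O)NC1CCCCC1)Nc1cccc(-c2csc(N)n2)c1`: "not determined" (no result reported)

Going by the values given here, in a functional assay on HEK293T cells for agonist activity at histamine H2 receptor (Homo sapiens), read by beta-arrestin recruitment (a higher number here means a larger maximal response, a lower number a smaller maximal response), compound 1 gives 0.32, the only number in this set; compound 2 and compound 3 share the aminothiazole and acylguanidine motifs but carry no result, so nothing can be said of how they compare. Compound 4, `CCCCCCNC(=O)/N=C(\N)NCCCc1sc(N)nc1C`, differs from compound 1 in one place: propyl in place of hydrogen on a saturated chain carbon, three bonds along the chain from an amide-type nitrogen. Among the compounds with values here, with no measured pair showing a step of this kind, the size of the step in this assay from compound 1 to compound 4 cannot be read from the data; a change at most of modest size, in either direction, is expected, and possibly none beyond the scatter. Compound 4 is therefore estimated at 0.35, with a range from 0.15 to 0.55, corresponding to an expected step a number 0.030 higher from compound 1 to compound 4 (within the scatter).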

Compound 4, intrinsic activity: the largest response reached, as a fraction of the reference agonist's: 0.28
Beside the measured number, compound 4's estimate is 0.070 above it; low and high end bracket the measured number.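

In this assay the step is a number 0.040 lower from compound 1 to compound 4 (within the scatter) and so the two compounds read alike: a hexyl chain in compound 4 gives the same maximal response, within the scatter, as the propyl chain in compound 1. Adding propyl at this saturated chain carbon, three bonds along the chain from an amide-type nitrogen, therefore leaves this read-out in place. Nothing at hand accounts for this result. From the compounds shown here alone, whether a longer chain such as octyl would behave likewise remains open. So does the effect of a terminal amine or carboxylic acid on the chain in this place.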